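A few compounds are considered here, and "the series" means these few. Any claim that something is new, unique, unknown or untested is made for them only; others in the source may bear on it.

Of the compounds shown here, three have so far been measured in an assay on membranes from brain for binding affinity to adenosine receptor A1 (Rattus norvegicus), read by radioligand binding; a higher number here means a weaker inhibitor, a lower number a stronger inhibitor. Compound 1 `Cn1c(=O)c2nc(-c3ccncc3)[nH]c2n(C)c1=O` gives 35 nM. Compound 2 `Cc1nn(C)c2c(O)nc(-c3ccc(Cl)cc3)nc12` has a different core and gives 410 nM, which is the second highest of the three numbers; its nearest neighbour is compound 1, and its furthest is compound 3 `Cc1nn(C)c2c(O)nc(-c3ccc(Cl)cc3[N+](=O)[O-])nc12`, which gives 8500 nM. Going by the values given here, the only measured pair that differs in a single place is the one from compound 2 to compound 3: a 21-fold higher number from compound 2 to compound 3 (1.32 log units; beyond the scatter), a large loss of binding after one small group is added to the aromatic ring that carries the chloro.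

Compound 4 `Cc1nn(C)c2c(O)nc(-c3ccc(S(=O)(=O)NCCN(C)C)cc3)nc12` has not yet been measured. It differs from compound 2 in one place: (2-(dimethylamino)ethyl)sulfamoyl in place of chloro on an aromatic carbon. Among the compounds with values here, no measured step covers an exchange of the chloro itself, so the only guide is that the one change made on this ring so far cost a great deal, and that the new group is far larger than the chloro it replaces. A weaker binder than compound 2 is therefore expected, though not by as much as the measured step showed. Compound 4 is estimated at 1200 nM, with a range from 300 nM to 6000 nM. That estimate amounts to an expected step of a 2.9-fold higher number from compound 2 to compound 4 (0.47 log units; beyond the scatter).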

Compound 4, half-maximal inhibitory concentration: 68 nM
Compound 4: the middle estimate sits 18-fold (1.25 log units) above what was measured; the measured number lies below the stated range.
By their numbers in this assay, from the lowest: compounds 1 and 4 (each within the scatter of the next); then compound 2; then compound 3.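

In this assay, the place held by the chloro of compound 2 does not demand a small group: replacing that single atom with (2-(dimethylamino)ethyl)sulfamoyl, which brings 9 heavy atoms, gives a 6.0-fold lower number from compound 2 to compound 4 (0.78 log units; beyond the scatter) and so a stronger binder. Going by these compounds alone, the only earlier change on this ring, a 21-fold higher number from compound 2 to compound 3 (1.32 log units; beyond the scatter), put a nitro in place of a hydrogen and left the chloro in place, so its large loss does not extend to every change on this ring, and adding bulk here does not by itself weaken binding. Nothing available here accounts for the gain, so the size of this step can be reported but not explained.

From the compounds shown here alone, it remains open which part of the new group matters: the sulfamoyl alone, with only its hydrogens on the nitrogen, would test whether the chain is needed at all, while a shorter chain or a longer one would show how much its length counts. Swapping the terminal dimethylamino for a carboxylic acid or a hydroxyl would show whether that end of the chain contributes to the gain.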